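A few compounds are considered here, and "the series" means these few. Any claim that something is new, unique, unknown or untested is made for them only; others in the source may bear on it.

Measured compounds in a functional assay on SW1573 cells (Homo sapiens) for inhibition, read by sulforhodamine B assay, with a stated time of 48 h; on this read-out lower numbers stand for stronger inhibition of growth and higher numbers for weaker inhibition of growth:
compound 1 `COC(=O)[C@@]1(C)CCC=C2[C@@H]1CC[C@@H](C)[C@]2(C)Cc1c[nH]c2ccc(C)cc12` gives 15000 nM
compound 2 `COC(=O)[C@@]1(C)CCC=C2[C@@H]1CC[C@@H](C)[C@]2(C)Cc1c[nH]c2ccc(Br)cc12` gives 12000 nM
compound 3 `COC(=O)[C@@]1(C)CC[C@@H]2C3=C1CC[C@@H](C)[C@]3(C)Cc1c2[nH]c2c(C)cccc12` gives 16000 nM

Compound 1 and compound 2 share one core and differ in one place: bromo in place of methyl on an aromatic carbon. This change gave a 1.3-fold lower number from compound 1 to compound 2 (0.10 log units; within the scatter), so the two values are read as equivalent within the usual scatter. Compound 3 has another core; how the core of compound 3 differs from that of compound 1 is not broken down here. In this assay the value of compound 3 lies within the scatter of the values of compound 1 and compound 2, and no order among the three is claimed.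

Compound 4 `COC(=O)[C@@]1(C)CC[C@@H]2C3=C1CC[C@@H](C)[C@]3(C)Cc1c2[nH]c2c(Br)cccc12` is not yet measured. It arises from compound 3 by bromo in place of methyl on an aromatic carbon. Among the measured compounds shown here, this is the same kind of change as the one from compound 1 to compound 2, not the same: around the place it sits, in compound 4 the aromatic carbon is part of a fused or bridged system of five rings, ortho to a fused ring and meta to a fused ring, whereas in compound 2 it is part of a fused or bridged system of two rings, meta to a fused ring and para to a fused ring.

In this assay, for the measured compounds named here, the step from compound 3 to compound 4 is expected to be a 1.2-fold lower number from compound 3 to compound 4 (0.09 log units; within the scatter), because the only precedent, a 1.3-fold lower number from compound 1 to compound 2 (0.10 log units; within the scatter), stayed within the scatter. The wider range allows for the different surroundings of the place and the different core. Compound 4 is therefore estimated at 13000 nM in this assay, between 6000 nM and 30000 nM.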

Compound 4, concentration for 50% growth inhibition: 26000 nM
Beside the measured number, compound 4's estimate is 2.0-fold (0.30 log units) below it, within the range that was stated.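

In this assay, bromo in place of methyl on an aromatic carbon gave a 1.6-fold higher number from compound 3 to compound 4 (0.21 log units; within the scatter), so compound 3 and compound 4 are read as equivalent, as compound 1 and compound 2 were. Set side by side, the two steps do not differ beyond what repeated measurement allows: the same change on two cores in this assay, a 1.3-fold lower number (0.10 log units; within the scatter) from compound 1 to compound 2 and a 1.6-fold higher number (0.21 log units; within the scatter) from compound 3 to compound 4, 2.0-fold (0.31 log units) apart, within the scatter of two such steps. This shows that the exchange stayed within the scatter on both cores, but it does not show that the change carries over from one core to another with a fixed size or direction: two steps of this kind fix neither, and the surroundings of the aromatic carbon also differ between the two cores.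

The compounds shown leave open whether a different kind of group on this aromatic carbon, such as an amine, a carboxylic acid or a longer alkyl chain, would move the number beyond the scatter on either core. On these data alone, it is also open whether any change away from this aromatic carbon, for example a carboxylic acid or an amide in place of the methyl ester, would separate the values.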